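Swapping the aryl group on the shared core

This account rests on a few compounds, and the source may have more. Where it says the series, first, only, none or still open, it means among the compounds named here.

In a functional assay on A549 cells (Homo sapiens) for inhibition, read by CCK-8 assay, with a stated time of 48 h (a higher number here means a weaker inhibitor, a lower number a stronger inhibitor), compound 1 `COc1cc(-c2ccnc3cc(-c4ccc(C(F)(F)F)cc4)nn23)cc(OC)c1OC` gives 2070 nM and compound 2 `C=Cc1ccc(-c2cc3nccc(-c4cc(OC)c(OC)c(OC)c4)n3n2)cc1` gives 1030 nM. Among the compounds with values here, the single measured step, a 2.0-fold lower number from compound 1 to compound 2 (0.30 log units; within the scatter), is vinyl in place of trifluoromethyl on an aromatic carbon. Within the data shown here, it lies within the scatter, so compound 2 stands level with its only neighbour and the series has no measured potency gap yet.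

Compound 3 `COc1ccc(-c2cc3nccc(-c4cc(OC)c(OC)c(OC)c4)n3n2)cc1N` carries 3-amino-4-methoxyphenyl in place of 4-vinylphenyl on an aromatic carbon of the five-membered aromatic ring: 3-amino-4-methoxyphenyl in place of 4-vinylphenyl on an aromatic carbon. This change replaces the whole aryl group, whereas a 2.0-fold lower number from compound 1 to compound 2 (0.30 log units; within the scatter) exchanged only one substituent on it. Among the measured compounds shown here, that measured step therefore sets no size for the new one, and no compound so far carries an amino or methoxy group on this aryl ring. A move towards a lower number in this assay is a tentative expectation, not a trend drawn from the data, and the range stays wide on both sides. The expected size is a 5.2-fold lower number from compound 2 to compound 3 (0.71 log units; beyond the scatter). For compound 3 the estimated value is 200 nM, with an expected range from 20 nM to 1500 nM.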

Compound 3, half-maximal inhibitory concentration: 138 nM
Beside the measured number, compound 3's estimate is 1.4-fold (0.16 log units) above it, and the stated range covers the measured number.
By their numbers in this assay, from the lowest: compound 3; then compounds 2 and 1 (each within the scatter of the next).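

Working notes: in this assay the aryl group on this aromatic carbon of the five-membered aromatic ring now has a measured effect, with a 7.5-fold lower number from compound 2 to compound 3 (0.87 log units; beyond the scatter) and a 15-fold lower number from compound 1 to compound 3 (1.18 log units; beyond the scatter) against a single earlier step that stayed within the scatter. Within the data shown here, the position therefore tolerates an aryl group bearing amino and methoxy substituents, and 3-amino-4-methoxyphenyl, which brings in a hydrogen-bond donor and acceptors absent from 4-vinylphenyl, is the first replacement here to separate a compound from the others. Because the whole aryl group changes in both steps, the amino and methoxy groups cannot be told apart as contributors, and no supporting evidence bears on this result.

Still open, going by these compounds, is whether either substituent alone would account for the step, which a phenyl ring carrying only the amino group or only the methoxy group would address. Also open, on these data alone, is how far the amino group itself can be varied, for instance by a hydroxyl group, a dimethylamino group or an acetamide at that place on the ring, and whether the other aryl group on the shared core responds to change at all.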